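Cyclohexyl versus isobutyl on the enaminone nitrogen: all at the limit

The compounds below may be only part of what the source reports. "The series", "measured", "known", "first", "only" and "open" are said of these compounds alone.

Compound 1 `COc1cc(/C=C/C(=O)/C=C(/C=C/c2ccc(OC(C)=O)c(OC)c2)NC2CCCCC2)ccc1OC(C)=O` and compound 2 `COc1cc(/C=C/C(=O)/C=C(/C=C/c2ccc(OC(C)=O)c(OC)c2)NCC(C)C)ccc1OC(C)=O` share one core; compound 3 `COc1cc(/C=C/C(=O)/C=C(/C=C/c2ccc(O)c(OC)c2)NC2CCCCC2)ccc1O` and compound 4 `COc1cc(/C=C/C(=O)/C=C(/C=C/c2ccc(O)c(OC)c2)NCC(C)C)ccc1O` share another. The difference between the two cores is not broken down here. Within each pair the change is the same: isobutyl in place of cyclohexyl on an amine nitrogen and (isobutyl in place of cyclohexyl on an amine nitrogen).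

In an ADME assay on EA.hy 926 cells (Homo sapiens) for inhibition, read by MTT assay, with a stated time of 72 h (a higher number here means a weaker inhibitor, a lower number a stronger inhibitor), compound 1 gives > 25000 nM, which is a limit of the assay and not a number. In this assay compound 2 likewise gives only the limit > 25000 nM. The step that the two limits leave unreadable from compound 1 to compound 2 therefore cannot be read. In this assay compound 3 also gives only the limit > 25000 nM. Within the data shown here, every value measured so far sits at the limit of > 25000 nM in this assay, at which 3 of the 3 values shown sit.

Compound 4 has not yet been measured in this assay. No readable step exists to carry over from the measured pair. Because every measured value sits at the limit of > 25000 nM in this assay, at which 3 of the 3 values shown sit, compound 4 is expected to remain at the limit as well, an expected step that the limit leaves unreadable from compound 3 to compound 4. The estimate for compound 4 is 40000 nM, expected to fall between 20000 nM and 120000 nM, most likely reported again only as a limit.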

Compound 4, half-maximal inhibitory concentration: > 25000 nM
Compound 4 was reported as a limit; the forecaster's own chance of this, stated with the estimate: 85%; the middle value is on the limit's open side.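

In this assay compound 4 gives > 25000 nM, a limit of the assay and not a number. No step can be read for isobutyl in place of cyclohexyl between compound 3 and compound 4. The compounds shown leave open whether the two nitrogen groups or the two cores differ in inhibition at all, because every value sits at one limit: the limit of > 25000 nM in this assay, at which 4 of the 4 values shown sit.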